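Swapping a Nitrile for a Methylsulfonyl Group

This account rests on a few compounds, and the source may have more. Where it says the series, first, only, none or still open, it means among the compounds named here.

Compound 1 `CC(C)(C)OC(=O)N1CCN(C(=O)c2cn(-c3nc4ccccc4s3)nn2)CC1`: 7.12 nM
Compound 2 `CC(C)(C)OC(=O)N1CCN(C(=O)c2cn(-c3ccc(C#N)cc3F)nn2)CC1`: 4.21 nM

Of the compounds shown here, two sharing the same core have been measured in an assay on HEK293 cells for agonist activity at Glucose-dependent insulinotropic receptor (Homo sapiens), read by a luciferase reporter, with a stated time of 24 h; on this read-out higher numbers stand for an effect only at larger amounts of compound and lower numbers for an effect already at smaller amounts. Compound 2 stands next to compound 1 within the scatter: the step of a 1.7-fold lower number from compound 1 to compound 2 (0.23 log units; within the scatter) does not separate the two, so neither can be called more active than the other on these data.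

Compound 3 `CC(C)(C)OC(=O)N1CCN(C(=O)c2cn(-c3ccc(S(C)(=O)=O)cc3F)nn2)CC1` has not yet been measured. It differs from compound 2 in one place: methylsulfonyl in place of cyano on an aromatic carbon. Among the compounds with values here, no measured step bears directly on this change. Within the data shown here, the single step on record exchanges the whole group on the aromatic nitrogen rather than a substituent on the six-membered aromatic ring of carbon only, and it was itself within the scatter. There is therefore nothing in these data pointing to a shift in either direction beyond the scatter, though the uncertainty is larger than for a simple repeat measurement.

Compound 3 is estimated at 5.5 nM, with a range from 1.5 nM to 20 nM. That estimate means an expected step of a 1.3-fold higher number from compound 2 to compound 3 (0.12 log units; within the scatter), within the scatter.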

Compound 3, half-maximal effective concentration: 12.4 nM
For compound 3 the middle estimate is 2.3-fold (0.35 log units) below the measured one, within the range that was stated.
By their numbers in this assay, from the lowest: compounds 2, 1 and 3 (each within the scatter of the next, the first and the last beyond it).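

In this assay, within the data shown here, the substituent on this aromatic carbon, para to a large group, does make a measurable difference: the exchange gives a 2.9-fold higher number from compound 2 to compound 3 (0.47 log units; beyond the scatter), a modest change, but one that the only earlier step, a 1.7-fold lower number from compound 1 to compound 2 (0.23 log units; within the scatter), could not have revealed. The change replaces cyano, with 2 heavy atoms and 1 hydrogen-bond acceptor, with methylsulfonyl, with 4 heavy atoms and 2 hydrogen-bond acceptors, and compound 3 still gives a number in the low nanomolar range at 12.4 nM, so this larger group does not abolish activity on this read-out. The data shown offer no measurement that explains the rise in the number.

Among these compounds, with only two groups compared at this position, it remains open whether the number follows the count of heavy atoms, the count of hydrogen-bond acceptors, or neither, and a chlorine atom, a carboxamide or a carboxylic acid on the same aromatic carbon would help to tell these apart. Also open, on these data alone, is whether the step would keep its size with a hydrogen atom in place of the fluoro group.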